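The source may hold more compounds than are shown below. What is called first, only, known or untested is meant among the compounds shown, and "the series" means these compounds.

Three ureas built on one shared core have been measured in an assay on microsomes from intestine for inhibition of acyl-CoA:cholesterol acyltransferase (Oryctolagus cuniculus); on this read-out lower numbers stand for stronger inhibition and higher numbers for weaker inhibition. Compound 1 `Cc1cc(C)c(NC(=O)N(Cc2ccc(-c3n[nH]c(C)n3)cc2)C2CCCCCC2)c(C)c1` gives 120 nM. Compound 2 `Cc1cc(C)c(NC(=O)N(Cc2ccc(-c3cccs3)cc2)C2CCCCCC2)c(C)c1` gives 22 nM. Compound 3 `Cc1cc(C)c(NC(=O)N(Cc2ccc(-c3cc[nH]n3)cc2)C2CCCCCC2)c(C)c1` gives 52 nM, the second highest of the three numbers: the step of a 2.4-fold higher number from compound 2 to compound 3 (0.37 log units; beyond the scatter) shows it weaker than compound 2, while a 2.3-fold lower number from compound 1 to compound 3 (0.36 log units; beyond the scatter) places it ahead of compound 1. Compound 4 `Cc1cc(C)c(NC(=O)N(Cc2ccc(-c3ccn(C)n3)cc2)C2CCCCCC2)c(C)c1` differs from compound 3 by methyl in place of hydrogen on an aromatic nitrogen. For the measured compounds named here, none of the measured steps touches a hydrogen on a ring nitrogen; each swaps one five-membered ring for another, so no direct guide exists in these data. A step hardly beyond the scatter is therefore expected, a 1.3-fold lower number from compound 3 to compound 4 (0.11 log units; within the scatter). Compound 4 is estimated at 40 nM, within a range from 15 nM to 130 nM.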

Compound 4, half-maximal inhibitory concentration: 44 nM
The estimate for compound 4 lay 1.1-fold (0.04 log units) below the measured number; the range from low to high includes it.
By their numbers in this assay, from the lowest: compounds 2, 4 and 3 (each within the scatter of the next, the first and the last beyond it); then compound 1.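

In this assay, methyl on the aromatic nitrogen of the 1H-pyrazol-3-yl ring leaves the number within the scatter (a 1.2-fold lower number from compound 3 to compound 4 (0.07 log units; within the scatter)), so at this position the hydrogen can give way to methyl without a measurable loss of inhibition. The 1-methyl-1H-pyrazol-3-yl ring also stays within the scatter of the thiophen-2-yl ring (a 2.0-fold higher number from compound 2 to compound 4 (0.30 log units; within the scatter)) and is beyond the scatter of the 5-methyl-1H-1,2,4-triazol-3-yl ring (a 2.7-fold lower number from compound 1 to compound 4 (0.44 log units; beyond the scatter)). No measurement at hand explains why the methyl makes so little difference. On these data alone, whether an ethyl, a longer chain or a chain ending in an amine on this nitrogen would behave like methyl remains open.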